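This account rests on a few compounds, and the source may have more. Where it says the series, first, only, none or still open, it means among the compounds named here.

Working notes on the series. Among the measured compounds shown here, compound 1, `Cc1nc(-c2ccccc2)c(C(=O)N2CCN(c3ccccc3Cl)CC2)o1`, is the only member of the set with a numerical reading: in a functional assay on HL-60 cells (Homo sapiens) for inhibition, read by MTT assay, with a stated time of 72 h (a lower number here means a stronger inhibitor, a higher number a weaker inhibitor), compound 1 gives 124 nM. For the measured compounds named here, compound 2, `COc1cccc(N2CCN(C(=O)c3oc(C)nc3-c3cccc(F)c3)CC2)c1`, carries a 3-methoxyphenyl on the ring amine nitrogen together with a 3-fluorophenyl on the core and is recorded in this assay as "not active" (no number reported), without a number; it differs from compound 1 in two places, so no single step can be drawn from it. Compound 3, `COc1cc(OC)cc(N2CCN(C(=O)c3oc(C)nc3-c3ccccc3)CC2)c1`, has not been measured. It differs from compound 1 in one place: 3,5-dimethoxyphenyl in place of 2-chlorophenyl on an amine nitrogen in a ring. Going by the values given here, no measured pair isolates this change. Among the compounds with values here, the only hint is compound 2, where a methoxy-bearing group on the same ring amine nitrogen goes with no activity in this assay, and compound 3 puts two methoxy groups there. A step toward weaker inhibition beyond the usual scatter is expected for compound 3, a 12-fold higher number from compound 1 to compound 3 (1.08 log units; beyond the scatter). For compound 3 the expected value in this assay is 1500 nM, with a plausible span from 300 nM to 10000 nM, and a fair chance that only a limit is reported.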

Compound 3, half-maximal inhibitory concentration: 19.2 nM
For compound 3 the middle estimate is 78-fold (1.89 log units) above the measured one; measured number outside the range, below it.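

In this assay the aryl group on the ring amine nitrogen can be changed without losing activity: 3,5-dimethoxyphenyl in place of 2-chlorophenyl gives a 6.5-fold lower number from compound 1 to compound 3 (0.81 log units; beyond the scatter), so the 2-chlorophenyl is not needed for inhibition in this series. Methoxy groups on this aryl group are therefore compatible with a low number, which could not be seen from compound 2 alone; that compound differs from both measured compounds in two places, and no step can be read from it. No measurement on hand accounts for the size of this step.

The compounds shown leave open whether the lower number comes from the two methoxy groups or from the absence of the chlorine, a question that a plain phenyl or a 3,5-dimethylphenyl on the same nitrogen would separate. Also open, as far as these compounds go, is whether a single methoxy group with the unsubstituted phenyl on the core behaves like compound 3, or whether the 3-fluorophenyl on the core is what goes with the "not active" record of compound 2.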